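A few compounds are considered here, and "the series" means these few. Any claim that something is new, unique, unknown or untested is made for them only; others in the source may bear on it.

The series is compared in an assay for displacement of a labelled ligand from DNA repair protein REV1 (Homo sapiens), read by fluorescence polarization, with a stated time of 1 h; a higher number here means a weaker inhibitor, a lower number a stronger inhibitor. Compound 1 `CC(=O)N1CCC(C(=O)Nc2sc3c(c2C(=O)NC2CC2)CCC(C)C3)CC1` gives 4600 nM; compound 2 `CCCC1CCc2c(sc(NC(=O)C3CCN(C(C)=O)CC3)c2C(N)=O)C1` gives 11900 nM; compound 3 `CCc1cc(C(=O)OC)c(NC(=O)C2CCN(C(C)=O)CC2)s1` gives 28800 nM. Compound 2 stands second highest of the three numbers: its nearest neighbour is compound 3, whose number lies higher by a gap beyond the scatter, and its furthest is compound 1, whose number lies lower, again beyond the scatter. Compound 4 `CC(=O)N1CCC(C(=O)Nc2sc3c(c2C(N)=O)CCC(C)C3)CC1` has not yet been measured in this assay. It differs from compound 2 in one place: hydrogen in place of ethyl on a saturated chain carbon bound to a saturated ring carbon; cut one bond further out, the same change reads propyl to methyl. Among the compounds with values here, no measured pair shows this change on its own, so its size is not fixed by the data. Because compound 1 gives the lowest number of the three at 4600 nM, a modest move downward is expected for compound 4, though a step within the scatter would not surprise. The step from compound 2 to compound 4 is estimated as a 1.7-fold lower number from compound 2 to compound 4 (0.23 log units; within the scatter). Compound 4 is expected at 7000 nM, within a range of 3000 nM to 16000 nM.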

Compound 4, inhibition constant: 15700 nM
Compound 4: middle estimate off by 2.2-fold (0.35 log units), on the low side; measured number inside the range.
By their numbers in this assay, from the lowest: compound 1; then compounds 2, 4 and 3 (each within the scatter of the next, the first and the last beyond it).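

Hydrogen in place of ethyl on a saturated chain carbon bound to a saturated ring carbon, which also reads as propyl to methyl, gives a 1.3-fold higher number from compound 2 to compound 4 (0.12 log units; within the scatter) in this assay, so the propyl and methyl forms at this position are not told apart. Within the data shown here, at the amide-type nitrogen, hydrogen in place of cyclopropyl gives a 3.4-fold higher number from compound 1 to compound 4 (0.53 log units; beyond the scatter), the first one-place change that clears the scatter, although it is seen only once. No measurement on hand bears on why either step has its size.

As far as these compounds go, whether a chain longer than propyl, or an amine carried on that chain, would shift the number at the first position stays open. Also open, from the compounds shown here alone, is how a cyclobutyl or hydroxyethyl group on the amide-type nitrogen would compare with cyclopropyl.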